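A few compounds are considered here, and "the series" means these few. Any claim that something is new, unique, unknown or untested is made for them only; others in the source may bear on it.

Measured in a functional assay on cells (Mast cell, Rattus norvegicus, strain Wistar) for activation, read by fluorescence, with a stated time of 15 min; on this read-out higher numbers stand for an effect only at larger amounts of compound and lower numbers for an effect already at smaller amounts:
Compound 1 `CCCCCCCCCCCCCCCCCC(=O)CCCCCOP(=O)(O)OC[C@H](N)C(=O)O`: > 10000 nM
Compound 2 `CCCCCCCCCCCCCCCCCC(=O)OC[C@H](O)COP(=O)(O)OC[C@H](N)C(=O)O`: 1000 nM
Compound 3 `CCCCCCCCCCCCCCCCCC(=O)OC[C@@H](O)COP(=O)(O)OC[C@H](NC)C(=O)O`: > 10000 nM

Only compound 2 has a true number in this set. Compound 1 gives > 10000 nM, which is a limit of the assay and not a number. Compound 3 gives > 10000 nM, which is likewise only a limit. That value is the limit of > 10000 nM in this assay, at which 2 of the 3 values shown sit, so compound 3 has no measured position of its own in this assay.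

Compound 4 `CCCCCCCCCCCCCCCCCC(=O)OC[C@@H](O)COP(=O)(O)O[C@H]1CN[C@@H](C(=O)O)C1` has not yet been measured. It differs from compound 3 as follows: a group of 8 heavy atoms (5 carbon, 1 nitrogen, 2 oxygen; one five-membered non-aromatic ring with 1 hetero atom) in place of a group of 7 heavy atoms (4 carbon, 1 nitrogen, 2 oxygen; no ring), on an oxygen. The new group thus brings a five-membered non-aromatic ring with 1 hetero atom, where compound 3 has no ring.

Among the measured compounds shown here, no measured pair shows what such a change does, so no gain is expected in this assay, and any shift is expected to stay small. The expectation rests on compound 3, which stands at > 10000 nM. The expected change is a step that the limit leaves unreadable from compound 3 to compound 4. Compound 4 is expected to read 20000 nM, with an estimated range of 4000 nM to 100000 nM, and it may well be reported only as a limit.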

Compound 4, half-maximal effective concentration: > 10000 nM
Compound 4 was reported as a limit (the forecaster's own chance of this, stated with the estimate: 70%); the middle value is on the limit's open side.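

Compound 3 and compound 4 both stand only at a limit, so no step can be read between them: the limit of > 10000 nM in this assay, at which 3 of the 4 values shown sit.

The compounds shown leave open whether the five-membered non-aromatic ring with 1 hetero atom, on an oxygen, changes the read-out in this assay at all.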